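This account rests on a few compounds, and the source may have more. Where it says the series, first, only, none or still open, it means among the compounds named here.

Measured so far:
Compound 1 `C=C1C[C@]23C[C@@]1(O)CC[C@H]2c1ccc(O)c(C)c1[C@@H]3Cn1cc(-c2ccc(Br)cc2)nn1` – in a functional assay on SMMC-7721 cells (Homo sapiens) for cytotoxicity, read by MTT assay, with a stated time of 4 days (a higher number here means a weaker inhibitor, a lower number a stronger inhibitor), compound 1 gives > 20000 nM, which is a limit of the assay and not a number.
Compound 2 `C=C1C[C@]23C[C@@]1(O)CC[C@H]2c1cc(Br)c(O)c(C)c1[C@@H]3Cn1cc(-c2ccc(F)cc2)nn1` – compound 2 gives > 20000 nM, again only a limit.

Compound 2 thus stands at the edge of what this assay can report, and every value shown sits there too (the limit of > 20000 nM in this assay, at which 2 of the 2 values shown sit). Compound 3 `C=C1C[C@]23C[C@@]1(O)CC[C@H]2c1ccc(O)c(C)c1[C@@H]3Cn1cc(-c2ccc(F)cc2)nn1` differs from compound 2 by hydrogen in place of bromo on an aromatic carbon. No measured step covers this change, so nothing shown speaks for a move beyond the usual scatter. The expected step from compound 2 to compound 3 in this assay is a step that the limit leaves unreadable from compound 2 to compound 3. Compound 3 is therefore estimated at 30000 nM, in a range from 15000 nM to 100000 nM, and most likely reported only as a limit.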

Compound 3, half-maximal inhibitory concentration: > 20000 nM
Compound 3 gave a limit, no number; the forecaster's own chance of this, stated with the estimate: 85%; the middle value is on the limit's open side.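

No step can be read among compound 1, compound 2 and compound 3, because each gives only a limit and no number: the limit of > 20000 nM in this assay, at which 3 of the 3 values shown sit.

These compounds leave open how weak each one really is, and whether exchanging bromo, fluoro or hydrogen changes anything.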